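Swapping the aryl group on the core nitrogen: a second test

A few compounds are considered here, and "the series" means these few. Any claim that something is new, unique, unknown or untested is made for them only; others in the source may bear on it.

Compound 1 `COc1ccc(-n2c(=O)c(C(=O)Nc3ccc(Oc4ccnc5c4ccn5C)cc3)cc3cccnc32)cc1`: 3460 nM
Compound 2 `Cn1ccc2c(Oc3ccc(NC(=O)c4cc5cccnc5n(-c5ccc(F)c(Cl)c5)c4=O)cc3)ccnc21`: 820 nM
Compound 3 `COc1ccc(-n2c(=O)c(C(=O)Nc3ccc(Oc4ccnc5c4ccn5C)c(F)c3)cc3cccnc32)cc1`: 2750 nM

In a functional assay on A549 cells (Homo sapiens) for antiproliferative activity, read by MTT assay, with a stated time of 72 h (a higher number here means a weaker inhibitor, a lower number a stronger inhibitor), compound 1 gives 3460 nM, compound 2 gives 820 nM and compound 3 gives 2750 nM. The two cores differ by fluoro in place of hydrogen on an aromatic carbon, and that change made only a 1.3-fold lower number from compound 1 to compound 3 (0.10 log units; within the scatter). The change of interest, (3-chloro-4-fluorophenyl in place of 4-methoxyphenyl on an aromatic nitrogen), made a 4.2-fold lower number from compound 1 to compound 2 (0.63 log units; beyond the scatter). Compound 4 `Cn1ccc2c(Oc3ccc(NC(=O)c4cc5cccnc5n(-c5ccc(F)c(Cl)c5)c4=O)cc3F)ccnc21` carries the same change, (3-chloro-4-fluorophenyl in place of 4-methoxyphenyl on an aromatic nitrogen), on the core of compound 3, and the surroundings of the place are the same in both pairs. Because the step of a 4.2-fold lower number from compound 1 to compound 2 (0.63 log units; beyond the scatter) lies beyond the scatter while the core difference a 1.3-fold lower number from compound 1 to compound 3 (0.10 log units; within the scatter) does not, a step of about the same size is expected from compound 3 to compound 4, a 4.2-fold lower number from compound 3 to compound 4 (0.63 log units; beyond the scatter). Compound 4 is therefore estimated at 650 nM, between 300 nM and 1400 nM.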

Compound 4, half-maximal inhibitory concentration: 3560 nM
The estimate for compound 4 lay 5.5-fold (0.74 log units) below the measured number; the whole stated range lies below it.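

In this assay, the gain seen on the core of compound 1 did not carry over to the core of compound 3, where 3-chloro-4-fluorophenyl in place of 4-methoxyphenyl gave a 1.3-fold higher number from compound 3 to compound 4 (0.11 log units; within the scatter), so the step differs between the two cores: the same change on two cores in this assay, a 4.2-fold lower number (0.63 log units; beyond the scatter) from compound 1 to compound 2 and a 1.3-fold higher number (0.11 log units; within the scatter) from compound 3 to compound 4, 5.5-fold (0.74 log units) apart, beyond the scatter of two such steps. Read the other way, fluoro in place of hydrogen gave a 4.3-fold higher number from compound 2 to compound 4 (0.64 log units; beyond the scatter), so its step depends on the aryl group on the nitrogen: the same change on two cores in this assay, a 1.3-fold lower number (0.10 log units; within the scatter) from compound 1 to compound 3 and a 4.3-fold higher number (0.64 log units; beyond the scatter) from compound 2 to compound 4, 5.5-fold (0.74 log units) apart, beyond the scatter of two such steps. The two changes are therefore not additive in these four compounds, but this single pair of cores does not show why, nor how any other aryl group would behave.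

The compounds shown leave open whether a plain phenyl or a 4-chlorophenyl on the nitrogen would follow the core of compound 1 or that of compound 3. They also leave open whether chloro in place of that fluoro would behave the same way.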